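The source may report more compounds than this note shows. Statements on the series, on what has been measured and on what is new or still open speak of the compounds shown alone.

Working notes on the series, all read in a functional assay on HeLa cells (Homo sapiens) for inhibition, read by CCK-8 assay, with a stated time of 48 h; a higher number here means a weaker inhibitor, a lower number a stronger inhibitor. Compound 3 (`COc1ccc(NC(=O)NCCNS(=O)(=O)c2ccc(-c3ccccc3Oc3ccc([N+](=O)[O-])cc3)s2)cc1`) gives > 20000 nM, which is a limit and not a number. The change to compound 4 (`COc1ccc(NC(=O)NCCNS(=O)(=O)c2ccc(-c3ccccc3OCc3cccc(O)c3)s2)cc1`) is 3-hydroxybenzyl in place of 4-nitrophenyl on an oxygen on an aromatic ring.

Two measured compounds already carry the 3-hydroxybenzyl group on that oxygen. Compound 1 (`O=C(NCCNS(=O)(=O)c1ccc(-c2ccccc2OCc2cccc(O)c2)s1)Nc1cc(Cl)cc(Cl)c1`) gives > 50000 nM, also a limit. Compound 2 (`O=[N+]([O-])c1cccc(NC(=S)NCCNS(=O)(=O)c2ccc(-c3ccccc3OCc3cccc(O)c3)s2)c1`) gives 11100 nM. The step of an at least 4.5-fold lower number from compound 1 to compound 2 (0.65 log units; beyond the scatter) lies beyond the scatter, but that change sits on an amine nitrogen, so it bears on this change only indirectly. Among the measured compounds shown here, no measured step isolates the change on the oxygen.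

For the measured compounds named here, the expectation therefore rests on compound 2 at 11100 nM, the only number among compounds with this group. It also rests on compound 1 at > 50000 nM, which is a limit. Weak inhibition is expected to persist. The expected step is small, a number no higher from compound 3 to compound 4 (the limit leaves the size open), and may not exceed the scatter. For compound 4 the estimated value is 20000 nM, with an expected range of 8000 nM to 50000 nM.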

Compound 4, half-maximal inhibitory concentration: > 20000 nM
Compound 4: no number, only a limit; the forecaster's own chance of this, stated with the estimate: 45%; the middle value sits exactly at the limit.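

In this assay compound 4 gives > 20000 nM, which is a limit and not a number. The change to 3-hydroxybenzyl from 4-nitrophenyl on an oxygen on an aromatic ring therefore gives no readable difference, and the steps to compound 4 from compound 3 and from compound 1 cannot be read, as the values at both ends are limits: the limit of > 20000 nM in this assay, at which 2 of the 4 values shown sit. The one readable step, on an amine nitrogen, is an at least 1.8-fold higher number from compound 2 to compound 4 (0.25 log units; that floor lies within the scatter), and compound 2 remains the only compound shown with a number.

From the compounds shown here alone, how 3-hydroxybenzyl and 4-nitrophenyl on that oxygen compare stays open, as does whether the number for compound 2 goes with its sulfur or with its nitrophenyl group. Also open, going by these compounds, is what an amine or a carboxylic acid in place of the hydroxy of 3-hydroxybenzyl would give in this assay.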